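Five-membered heteroaryl groups on a shared urea core

This account rests on a few compounds, and the source may have more. Where it says the series, first, only, none or still open, it means among the compounds named here.

Measured in an assay on microsomes from intestine for inhibition of acyl-CoA:cholesterol acyltransferase (Oryctolagus cuniculus); on this read-out higher numbers stand for weaker inhibition and lower numbers for stronger inhibition:
Compound 1, `Cc1cc(C)c(NC(=O)N(Cc2ccc(-c3n[nH]c(C)n3)cc2)C2CCCCCC2)c(C)c1`, gives 120 nM.
Compound 2, `Cc1cc(C)c(NC(=O)N(Cc2ccc(-c3ccsc3)cc2)C2CCCCCC2)c(C)c1`, gives 19 nM.
Compound 3, `Cc1cc(C)c(NC(=O)N(Cc2ccc(-c3ccn(C)n3)cc2)C2CCCCCC2)c(C)c1`, gives 44 nM.

Compound 3 stands second highest of the three numbers in this assay. The step of a 2.3-fold higher number from compound 2 to compound 3 (0.36 log units; beyond the scatter) and the step of a 2.7-fold lower number from compound 1 to compound 3 (0.44 log units; beyond the scatter) both lie beyond the scatter, so compound 3 sits clearly between its two neighbours. The largest step, a 6.3-fold lower number from compound 1 to compound 2 (0.80 log units; beyond the scatter), is still only modest.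

Compound 4, `Cc1cc(C)c(NC(=O)N(Cc2ccc(-n3ccnc3)cc2)C2CCCCCC2)c(C)c1`, has not been measured. It differs from compound 3 in one place: 1H-imidazol-1-yl in place of 1-methyl-1H-pyrazol-3-yl on an aromatic carbon. Among the compounds with values here, no measured step exchanges one six-atom five-membered heteroaryl for a five-atom one of the same ring size, so the three steps above give only the scale of what such exchanges did here: all modest. Compound 4 is therefore expected to land close to compound 3 in this assay, with a step of a 1.4-fold higher number from compound 3 to compound 4 (0.13 log units; within the scatter), perhaps a little toward a higher number. The estimate for compound 4 is 60 nM, within 25 nM to 150 nM.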

Compound 4, half-maximal inhibitory concentration: 47 nM
Compound 4: the middle estimate sits 1.3-fold (0.11 log units) above what was measured; the measured number falls inside the stated range.
By their numbers in this assay, from the lowest: compound 2; then compounds 3 and 4 (each within the scatter of the next); then compound 1.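

In this assay, a 1.1-fold higher number from compound 3 to compound 4 (0.03 log units; within the scatter) shows that at this position, para to a large group, 1H-imidazol-1-yl with 5 heavy atoms cannot be told apart from 1-methyl-1H-pyrazol-3-yl with 6. Compound 4 also stands much where compound 3 stood relative to the other two, with a 2.5-fold higher number from compound 2 to compound 4 (0.39 log units; beyond the scatter) and a 2.6-fold lower number from compound 1 to compound 4 (0.41 log units; beyond the scatter), so thiophen-3-yl still gives the lowest number and 5-methyl-1H-1,2,4-triazol-3-yl the highest. Nothing measured on these compounds accounts for these differences.

The compounds shown leave open whether a methyl group on the 1H-imidazol-1-yl ring would change the number. They also leave open how a dimethylamino group or a carboxylic acid would fare at this position in place of a five-membered aromatic ring.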